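From pyridin-3-yl to pyridin-2-yl on a carbonyl carbon

This account rests on a few compounds, and the source may have more. Where it says the series, first, only, none or still open, it means among the compounds named here.

Compound 1 `CCCCc1ccc2[nH]c(-c3ccc(C(F)(F)F)cc3)c(C=O)c2c1` gives 33 nM 
Compound 2 `CCCCc1ccc2[nH]c(-c3ccc(C(F)(F)F)cc3)c(/C=N/NC(=O)c3ccc(Cl)cc3)c2c1` gives 329 nM 
Compound 3 `CCCCc1ccc2[nH]c(-c3ccc(C(F)(F)F)cc3)c(/C=N/NC(=O)c3cccnc3)c2c1` gives 97 nM 

In a functional assay on MDA-MB-231 cells (Homo sapiens) for antiproliferative activity, with a stated time of 4 days (a higher number here means a weaker inhibitor, a lower number a stronger inhibitor), compound 3 stands in the middle of the three numbers, higher than compound 1 and lower than compound 2. The next compound, compound 4 `CCCCc1ccc2[nH]c(-c3ccc(C(F)(F)F)cc3)c(/C=N/NC(=O)c3ccccn3)c2c1`, differs from it in one place: pyridin-2-yl in place of pyridin-3-yl on a carbonyl carbon. In short, it has pyridin-2-yl in place of pyridin-3-yl on a carbonyl carbon, with the same atoms joined differently.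

Two measured steps give a sense of scale. For the measured compounds named here, the first swaps a small group on the core for a much larger one (a 2.9-fold higher number from compound 1 to compound 3 (0.47 log units; beyond the scatter)). The second is closer, as only the group on the carbonyl carbon changes (a 3.4-fold lower number from compound 2 to compound 3 (0.53 log units; beyond the scatter)). Both are modest, and each replaces more than the change at hand does. Going by the values given here, no measured pair swaps one pyridinyl group for another, so the data give no direction.

Judged by that closer step (a 3.4-fold lower number from compound 2 to compound 3 (0.53 log units; beyond the scatter)), a smaller change is expected, quite possibly none beyond the scatter. The expected step is a 1.1-fold higher number from compound 3 to compound 4 (0.05 log units; within the scatter) on this estimate. For compound 4 the estimated value is 110 nM with an expected range from 40 nM to 300 nM in this measurement.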

Compound 4, half-maximal inhibitory concentration: 260 nM
Estimate against measurement, compound 4: 2.4-fold (0.37 log units) below; measured number inside the range.
By their numbers in this assay, from the lowest: compound 1; then compound 3; then compounds 4 and 2 (each within the scatter of the next).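

In this assay, the group on the carbonyl carbon proves sensitive to the place of the ring nitrogen alone (a 2.7-fold higher number from compound 3 to compound 4 (0.43 log units; beyond the scatter)), even though pyridin-3-yl and pyridin-2-yl have the same atoms, joined differently. The earlier advantage of pyridin-3-yl over 4-chlorophenyl (a 3.4-fold lower number from compound 2 to compound 3 (0.53 log units; beyond the scatter)) therefore does not extend to every pyridine ring, since pyridin-2-yl and 4-chlorophenyl cannot be told apart here (a 1.3-fold lower number from compound 2 to compound 4 (0.10 log units; within the scatter)). Compound 4 also widens the gap to compound 1, the compound with the much smaller group on the aromatic carbon (a 7.9-fold higher number from compound 1 to compound 4 (0.90 log units; beyond the scatter)), so neither pyridine compound matches it.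

The data offer no explanation for why the place of the ring nitrogen matters at this position. On these data alone, it remains open how pyridin-4-yl, or a pyridin-3-yl ring carrying an amine, would behave on the carbonyl carbon, and whether any group there could bring the number down to that of compound 1 (33 nM).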